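The source may report more compounds than this note shows. Statements on the series, on what has been measured and on what is new or still open speak of the compounds shown alone.

This study measures how strongly a small family of compounds sharing one core kill liver cancer cells, using a functional assay on SMMC-7721 cells (Homo sapiens) for cytotoxicity, read by MTT assay, with a stated time of 48 h; on this read-out lower numbers stand for stronger inhibition and higher numbers for weaker inhibition. Compound 1 `C=CC(=C)[C@@H](O)C[C@H]1C(=C)CC[C@@H]2[C@]1(C)CCC[C@]2(C)C(=O)O` carries a carboxylic acid on its core and a hydroxylated side chain bearing two double bonds. In this assay compound 1 gives only a limit, > 40000 nM, so no exact number is known for it; the reading sits at the upper edge of what this assay reports (the limit of > 40000 nM in this assay, at which 1 of the 2 values shown sits). Compound 2 `C=CC(=C)CC[C@@H]1[C@@]2(C)CCC[C@](C)(COC(=O)/C=C/c3ccc(O)c(OC)c3)[C@@H]2CC[C@@]1(C)O` belongs to the same family but carries an ester in place of the acid, and in this assay compound 2 gives 14100 nM. Among the measured compounds shown here, no pair of measured compounds differs in a single place, so the effect of one change on this read-out has not yet been observed directly.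

Compound 3 `C=C[C@@](C)(O)CC[C@H]1C(=C)CC[C@@H]2[C@]1(C)CCC[C@]2(C)C(=O)O` keeps the core and the acid of compound 1 and alters only the side chain: a group of 6 heavy atoms (5 carbon, 1 oxygen; no ring) in place of a group of 6 heavy atoms (5 carbon, 1 oxygen; no ring), on a saturated chain carbon bound to a saturated ring carbon. One of the two double bonds is lost while the hydroxyl remains. The step from a step that the limit leaves unreadable from compound 1 to compound 3 is expected to be small, not beyond the usual scatter. Compound 3 is therefore expected to give about 45000 nM, between 15000 nM and 120000 nM, and may well return only a limit again.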

Compound 3, half-maximal inhibitory concentration: > 40000 nM
Compound 3 was reported as a limit; the forecaster's own chance of this, stated with the estimate: 55%; the middle value lies beyond the limit too.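

Compound 1 and compound 3 each return only a limit in this assay, so the step between them cannot be read: the limit of > 40000 nM in this assay, at which 2 of the 3 values shown sit.

The compounds shown leave open how far any single change to the shared core or its side chain moves the exact value on this read-out.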